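A few compounds are considered here, and "the series" means these few. Any claim that something is new, unique, unknown or untested is made for them only; others in the source may bear on it.

Measured so far in a functional assay on HT-29 cells (Homo sapiens) for antiproliferative activity, read by sulforhodamine B assay, with a stated time of 72 h; on this read-out lower numbers stand for stronger inhibition and higher numbers for weaker inhibition:
- compound 1 `Cc1cc(C)nc(NS(=O)(=O)c2ccc(Nc3nncc4ccccc34)cc2)n1` gives 3.3 nM
- compound 2 `Clc1ccc(C(/C=C/c2ccccc2)=N\Nc2nncc3ccccc23)cc1` gives 2.3 nM

Compound 1 at 3.3 nM and compound 2 at 2.3 nM lie within the usual scatter of each other, so the two cannot be ranked. Compound 3 `NS(=O)(=O)c1ccc(Nc2nncc3ccccc23)cc1` is still unmeasured. It differs from compound 1 by hydrogen in place of 4,6-dimethylpyrimidin-2-yl on a sulfonamide nitrogen and carries hydrogen in place of 4,6-dimethylpyrimidin-2-yl on a sulfonamide nitrogen. Among the compounds with values here, no measured pair shows this change, so any expectation here is loose. In this assay a move towards weaker inhibition is expected, with a 3.6-fold higher number from compound 1 to compound 3 (0.56 log units; beyond the scatter) as the estimated step, probably beyond the scatter, though the range also allows for no real change. For compound 3 the estimated value is 12 nM with an expected range from 3 nM to 50 nM on present data.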

Compound 3, half-maximal inhibitory concentration: 12 nM
The estimate for compound 3 equals the measured number at the digits printed; low and high end bracket the measured number.
By their numbers in this assay, from the lowest: compounds 2 and 1 (each within the scatter of the next); then compound 3.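

In this assay, within the data shown here, this is the first readable step, and it falls on the sulfonamide nitrogen: hydrogen in place of 4,6-dimethylpyrimidin-2-yl gives a 3.6-fold higher number from compound 1 to compound 3 (0.56 log units; beyond the scatter). The substituent on this nitrogen therefore affects the read-out, but the step is modest, and the 4,6-dimethylpyrimidin-2-yl group is not required for activity, as compound 3 still gives 12 nM in this assay. No measurement in hand explains the step.

From the compounds shown here alone, it remains open whether the step depends on the whole 4,6-dimethylpyrimidin-2-yl group or on a smaller part of it, which a methyl, an acetyl or an unsubstituted pyrimidin-2-yl on the same nitrogen would help separate. Compound 2 differs from compound 1 and compound 3 in more than one place, so it cannot show whether the step carries over to another part of the series.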